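This account rests on a few compounds, and the source may have more. Where it says the series, first, only, none or still open, it means among the compounds named here.

Compound 3 `CCN(CC)C(=O)c1ccc(S(=O)(=O)N2CCC[C@@H](C(=O)N3CCN(c4nc(C(C)C)no4)CC3)C2)cc1` is the compound with the highest number among the two measured as numbers in an ADME assay on microsomes from liver (Homo sapiens) for metabolic stability, read by LC-MS, with a stated time of 60 min, tested at 10 uM; a higher number here means that the compound lasts longer, a lower number that the compound disappears faster: compound 3 gives 0.213 h. Its nearest neighbour, compound 2 `CCC(CC)S(=O)(=O)c1ccc(S(=O)(=O)N2CCC[C@@H](C(=O)N3CCN(c4nc(C(C)C)no4)CC3)C2)cc1`, gives 0.0422 h; the step of a 5.0-fold higher number from compound 2 to compound 3 (0.70 log units; beyond the scatter) is what separates them. Compound 1 `CC(C)c1noc(C2CCN(C(=O)[C@@H]3CCCN(S(=O)(=O)c4ccc(S(=O)(=O)C(C)C)cc4)C3)CC2)n1` belongs to a different core, and the value for compound 1 is a limit of this assay, > 1 h, as recorded in the limit of > 1 h in this assay, at which 1 of the 3 values shown sits, so it cannot be put in order against the other two.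

The compound now in question is compound 4 `CC(C)NS(=O)(=O)c1ccc(S(=O)(=O)N2CCC[C@@H](C(=O)N3CCN(c4nc(C(C)C)no4)CC3)C2)cc1`. It differs from compound 3 by isopropylsulfamoyl in place of diethylcarbamoyl on an aromatic carbon, the group sitting on an aromatic carbon of a six-membered aromatic ring of carbon only, para to a large group.

Among the compounds with values here, only one measured step touches this part of the molecule: a 5.0-fold higher number from compound 2 to compound 3 (0.70 log units; beyond the scatter), which swapped a sulfonyl-bearing group for an amide and moved the number modestly upward. Within the data shown here, the present change goes in another direction, from an amide to a sulfonamide, and no measured pair mirrors it, so a step of about the size of the usual scatter is expected, without a firm direction. The expected step is a 1.4-fold higher number from compound 3 to compound 4 (0.15 log units; within the scatter), and for compound 4 the estimate is 0.3 h, with a range from 0.1 h to 1 h.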

Compound 4, half-life: 0.056 h
Compound 4: the middle estimate sits 5.4-fold (0.73 log units) above what was measured; measured number outside the range, below it.
By their numbers in this assay, from the lowest: compounds 2 and 4 (each within the scatter of the next); then compound 3. At a limit, above all of these: compound 1.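

In this assay, the diethylcarbamoyl group on this aromatic carbon turns out to matter: putting isopropylsulfamoyl in its place gives a 3.8-fold lower number from compound 3 to compound 4 (0.58 log units; beyond the scatter), a step beyond the scatter. The other new comparison, a 1.3-fold higher number from compound 2 to compound 4 (0.12 log units; within the scatter), lies within the scatter, so isopropylamino and pentan-3-yl on the sulfonyl sulfur cannot be told apart, and among compounds 2, 3 and 4 only the amide stands apart. Within the data shown here, the single earlier step could not show whether a nitrogen in this group was enough to raise the number, but compound 4 carries a nitrogen in its isopropylsulfamoyl group and does not reach the number of compound 3.

No measurement shown explains why the amide and the two sulfonyl-bearing groups differ in this way. As far as these compounds go, it also remains open whether the higher number belongs to the carbonyl or to the two ethyl chains, a question that an isopropyl amide, which would set the same isopropylamino part on a carbonyl, could help to settle, while a carboxylic acid at this place would show what happens with no amine part at all.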